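Ortho-substituted anilino analogues: hydroxy to amino

The source may hold more compounds than are shown below. What is called first, only, known or untested is meant among the compounds shown, and "the series" means these compounds.

Three compounds of the series share one core and differ only at the substituent on the anilino ring. Compound 1 `COc1ccccc1Nc1nc(-c2cccc(F)c2)nc2ccc(F)cc12` carries a methoxy there; in a functional assay on COLO 205 cells (Homo sapiens) for cytotoxicity, read by MTT assay, with a stated time of 48 h (on this read-out higher numbers stand for weaker inhibition and lower numbers for stronger inhibition), compound 1 gives > 50000 nM, a limit of the assay and not a number. Compound 2 `Fc1cccc(-c2nc(Nc3ccccc3Cl)c3cc(F)ccc3n2)c1` carries a chloro; in this assay compound 2 gives > 50000 nM, again a limit. Compound 3 `Oc1ccccc1Nc1nc(-c2cccc(F)c2)nc2ccc(F)cc12` carries a hydroxy; in this assay compound 3 gives > 50000 nM, also a limit. All three values therefore sit at the limit of > 50000 nM in this assay, at which 3 of the 3 values shown sit, and the steps a step that the two limits leave unreadable from compound 1 to compound 2, a step that the two limits leave unreadable from compound 1 to compound 3 and a step that the two limits leave unreadable from compound 2 to compound 3 are unreadable in size; compound 3 stands nowhere distinguishable from its two neighbours.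

Compound 4 `Nc1ccccc1Nc1nc(-c2cccc(F)c2)nc2ccc(F)cc12` follows from compound 3 by amino in place of hydroxy on an aromatic carbon. The two steps that end at compound 3 bear on it, yet both are unreadable, so no direction can be drawn from them. The expected step of a number no higher from compound 3 to compound 4 (the limit leaves the size open) is therefore taken as none beyond the scatter. For compound 4 the estimate in this assay is 50000 nM, between 15000 nM and 150000 nM, most probably reported again only as a limit.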

Compound 4, half-maximal inhibitory concentration: > 50000 nM
Compound 4: a limit, no number; the forecaster's own chance of this, stated with the estimate: 80%; the middle value lies on the limit itself.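

In this assay compound 4 gives > 50000 nM, a limit and not a number. No step among compound 1, compound 2, compound 3 and compound 4 can be read: the limit of > 50000 nM in this assay, at which 4 of the 4 values shown sit.

The compounds shown leave open how the methoxy, chloro, hydroxy and amino analogues rank in this assay.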